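A Methoxyphenyl Variant of the Hexyl Acid Inhibitor

The compounds below may be only part of what the source reports. "The series", "measured", "known", "first", "only" and "open" are said of these compounds alone.

Compound 1, `CCCCC(Sc1nc(Cl)cc(Nc2nc(-c3ccc(Cl)cc3)cs2)n1)C(=O)O`: 900 nM
Compound 2, `O=C(O)CSc1nc(Cl)cc(Nc2nc(-c3ccc(Cl)cc3)cs2)n1`: > 10000 nM
Compound 3, `CCCCCCC(Sc1nc(Cl)cc(Nc2nc(-c3ccc(F)cc3F)cs2)n1)C(=O)O`: 1500 nM

In an assay for inhibition of Polyunsaturated fatty acid 5-lipoxygenase (Homo sapiens), read by HPLC, with stated times of 15 min and 10 min (on this read-out higher numbers stand for weaker inhibition and lower numbers for stronger inhibition), compound 3 stands highest of the two numbers recorded, with compound 1 the nearest, a gap that lies within the scatter. For compound 2 the value is a limit of the assay and not a number. Among the compounds with values here, the only measured step, an at least 11-fold higher number from compound 1 to compound 2 (1.04 log units; beyond the scatter), concerns the chain carbon and not the aryl group; the limit of > 10000 nM in this assay, at which 1 of the 3 values shown sits, is where compound 2 sits.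

Compound 4, `CCCCCCC(Sc1nc(Cl)cc(Nc2nc(-c3ccc(OC)cc3)cs2)n1)C(=O)O`, differs from compound 3 by 4-methoxyphenyl in place of 2,4-difluorophenyl on an aromatic carbon. Within the data shown here, no measured step bears on an exchange of this aryl group, so no shift beyond the scatter is expected, and the estimated step is no change at the digits printed from compound 3 to compound 4 (within the scatter). Compound 4 is therefore expected to give 1500 nM, within the range 500 nM to 5000 nM.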

Compound 4, half-maximal inhibitory concentration: 800 nM
Estimate against measurement, compound 4: 1.9-fold (0.27 log units) above; low and high end bracket the measured number.
By their numbers in this assay, from the lowest: compounds 4, 1 and 3 (each within the scatter of the next). At a limit, above all of these: compound 2.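

In this assay, the exchange of 2,4-difluorophenyl for 4-methoxyphenyl on the aromatic carbon of the five-membered ring gives a 1.9-fold lower number from compound 3 to compound 4 (0.27 log units; within the scatter), with the hexyl acid chain unchanged. Within the data shown here, this is the first step read at this position, and it does not separate the two aryl groups, whereas the only earlier step concerned the chain carbon. No measurement shown here bears on this exchange.

As far as these compounds go, whether a 4-aminophenyl or a pyridine ring at this place would move the number beyond the scatter stays open. So does the effect of a chain longer than hexyl.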